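Lengthening the sulfonyl chain: compound 3 to compound 4

This account rests on a few compounds, and the source may have more. Where it says the series, first, only, none or still open, it means among the compounds named here.

Of the compounds shown here, three on a shared core have numbers so far: compound 1 `CCCCCCS(=O)(=O)c1ccc(O)c(C(=O)Nc2ccc(Br)cc2)c1`, compound 2 `CCCCS(=O)(=O)c1ccc(O)c(C(=O)Nc2ccc(Br)cc2)c1` and compound 3 `CCCCS(=O)(=O)c1ccc(O)c(C(=O)Nc2ccc(C(F)(F)F)cc2)c1`. In a physicochemical assay for lipophilicity (a lower number here means a more polar compound, a higher number a more lipophilic compound), compound 3 gives 3.1. Compound 1 gives 3.2, within the scatter of compound 3. Compound 2 gives 2.48, the lowest of the three and beyond the scatter of both others.

Compound 4 `CCCCCCCCCCCCS(=O)(=O)c1ccc(O)c(C(=O)Nc2ccc(C(F)(F)F)cc2)c1` is the next case. Its difference from compound 3 is octyl in place of hydrogen on a saturated chain carbon, four bonds along the chain from a sulfonyl sulfur.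

Within the data shown here, the closest precedent is a number 0.72 log units lower from compound 1 to compound 2 (beyond the scatter), a modest step for hydrogen in place of ethyl at the same place. Read in reverse, it points upward for a longer chain. Octyl holds far more carbon than ethyl, so scaling by carbon count implies a large rise. The other measured step, a number 0.62 log units higher from compound 2 to compound 3 (beyond the scatter), swaps bromo for trifluoromethyl and does not bear on the chain. No chain longer than that of compound 1 has been measured, so the estimate sits somewhat under strict proportion, with a wide range.

The expected change is a number 2.50 log units higher from compound 3 to compound 4 (beyond the scatter), upward and well beyond the scatter.

For compound 4 the estimated value is 5.6, with an expected range of 4.7 to 6.4.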

Compound 4, distribution coefficient: 6.2
For compound 4 the middle estimate is 0.60 log units below the measured one; low and high end bracket the measured number.
By their numbers in this assay, from the lowest: compound 2; then compounds 3 and 1 (each within the scatter of the next); then compound 4.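

At the saturated chain carbon four bonds along the chain from the sulfonyl sulfur, octyl in place of hydrogen gives a number 3.10 log units higher from compound 3 to compound 4 (beyond the scatter) in this assay, so this position can carry a large step, whereas the earlier change here, a number 0.72 log units lower from compound 1 to compound 2 (beyond the scatter) for hydrogen in place of ethyl, was modest. The new step also extends the chain comparison to a compound with trifluoromethyl, while the earlier chain step was read on compounds with bromo; once the earlier step is read in reverse, both move the number the same way, and the larger chain change goes with the larger step. No measurement in hand explains the size of either step.

With only these two steps at this position, the compounds shown leave open whether the number climbs evenly with each added carbon or levels off, and how a longer chain would read. They also leave open how the number would respond to an amine or a carboxylic acid on that saturated chain carbon in place of a plain carbon chain.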